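Swapping a halogenated phenyl ring on a piperazine sulfonamide

The source may hold more compounds than are shown below. What is called first, only, known or untested is meant among the compounds shown, and "the series" means these compounds.

Three compounds built on a shared core carry an arylsulfonyl piperazine whose far nitrogen bears an aromatic ring. Compound 1 `CCCn1c(=O)[nH]c2nc(-c3ccc(S(=O)(=O)N4CCN(c5ccccc5Br)CC4)cc3)[nH]c2c1=O` has a 2-bromophenyl there, compound 2 `CCCn1c(=O)c2[nH]c(-c3ccc(S(=O)(=O)N4CCN(c5ccc(Cl)cc5)CC4)cc3)nc2n(C)c1=O` a 4-chlorophenyl together with a methyl on the core, and compound 3 `CCCn1c(=O)[nH]c2nc(-c3ccc(S(=O)(=O)N4CCN(c5ccccc5)C(C)C4)cc3)[nH]c2c1=O` a plain phenyl with a methyl on the piperazine. In an assay on CHO cells for displacement of a labelled ligand from adenosine receptor A1 (Homo sapiens), read by scintillation counting, with a stated time of 90 min, tested at 1 uM, in the presence of a further agent that is not named here (on this read-out lower numbers stand for less inhibition and higher numbers for more inhibition at the one concentration tested (going by the name of the read-out)), compound 1 gives 28%. Compound 2 gives 22%, which sits within the usual scatter of the number for compound 1. Compound 3 gives 15%, a number that lies beyond that scatter below compound 1.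

Compound 4 `CCCn1c(=O)[nH]c2nc(-c3ccc(S(=O)(=O)N4CCN(c5ccc(I)cc5)CC4)cc3)[nH]c2c1=O` differs from compound 1 in one place: 4-iodophenyl in place of 2-bromophenyl on an amine nitrogen in a ring. Among the measured compounds shown here, no measured pair shows what such a swap does in this assay, so the expectation rests on the spread of the three numbers alone. The step from compound 1 to compound 4 is expected to be small, most likely none beyond the scatter, as a number 3 percentage points lower from compound 1 to compound 4 (within the scatter). Compound 4 is therefore estimated to give about 25% in this assay, with a range from 8% to 45%.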

Compound 4, a percentage reported as inhibition, at one concentration (the size of the read-out at that concentration, not a potency): 24%
Compound 4: middle estimate off by 1 percentage points, on the high side; the measured number falls inside the stated range.
By their numbers in this assay, from the lowest: compounds 3, 2, 4 and 1 (each within the scatter of the next, the first and the last beyond it).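

Among the compounds shown here, the first change in one place at this position in this assay gives a number 4 percentage points lower from compound 1 to compound 4 (within the scatter). Here the pair of compounds does what the three earlier, more loosely related compounds could not: it shows that replacing 2-bromophenyl with 4-iodophenyl on this amine nitrogen leaves the read-out within the usual scatter. The swap changes both the halogen and its place on the phenyl ring, and no available evidence explains the result.

The compounds shown leave open whether the two parts of this swap each have little effect or whether their effects offset each other, a question that a 4-bromophenyl group on the same nitrogen could help settle. They also leave open how a group of another kind, such as benzyl or acetyl, would read out at this nitrogen.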